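This account rests on a few compounds, and the source may have more. Where it says the series, first, only, none or still open, it means among the compounds named here.

Compound 3 `COc1ccc(F)cc1CNCCCNc1ccnc2cc(CC(C)C)ccc12` gives 4200 nM in a physicochemical assay for solubility, with a stated time of 18 h, at pH 7.4; on this read-out lower numbers stand for lower solubility and higher numbers for higher solubility. Among the compounds with values here, compound 2 `COc1ccc(F)cc1CNCCCNc1ccnc2cc(CCc3ccccc3)ccc12` gives 4200 nM in this assay, and no change at the digits printed from compound 2 to compound 3 (within the scatter), so compound 3 stands level with compound 2, the two together giving the lowest of the three known numbers. Compound 1 `COc1ccc(Oc2ccc3c(NCCCNCc4cc(F)ccc4OC)ccnc3c2)cc1` gives 14500 nM in this assay, the highest of the three; a 3.5-fold lower number from compound 1 to compound 2 (0.54 log units; beyond the scatter), and a 3.5-fold lower number from compound 1 to compound 3 (0.54 log units; beyond the scatter).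

Compound 4 `COc1ccc(F)cc1CNCCCNc1ccnc2cc(Oc3ccc(C(C)(C)C)cc3)ccc12` has not yet been measured. Against compound 3 it differs in one place: 4-(tert-butyl)phenoxy in place of isobutyl on an aromatic carbon. Within the data shown here, the step that bears on this is the one from compound 1 to compound 3, where 4-methoxyphenoxy on the same aromatic carbon of the shared core gave way to isobutyl, with a 3.5-fold lower number from compound 1 to compound 3 (0.54 log units; beyond the scatter). Compound 4 runs that change in the opposite direction, putting 4-(tert-butyl)phenoxy in place of isobutyl rather than restoring 4-methoxyphenoxy, so only part of the return toward the value of compound 1 is expected. The expected step is a 1.7-fold higher number from compound 3 to compound 4 (0.22 log units; within the scatter). Compound 4 is estimated at 7000 nM, with a range from 2500 nM to 20000 nM.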

Compound 4, solubility: 14500 nM
Beside the measured number, compound 4's estimate is 2.1-fold (0.32 log units) below it; the range from low to high includes it.
By their numbers in this assay, from the lowest: compounds 2 and 3 (each within the scatter of the next); then compounds 1 and 4 (each within the scatter of the next).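

In this assay the higher number seen with 4-methoxyphenoxy is not tied to its methoxy group: on this aromatic carbon, 4-(tert-butyl)phenoxy in place of isobutyl gives a 3.5-fold higher number from compound 3 to compound 4 (0.54 log units; beyond the scatter) and in place of phenethyl gives a 3.5-fold higher number from compound 2 to compound 4 (0.54 log units; beyond the scatter) on the shared core. Tert-butyl in place of methoxy on the phenoxy ring gives no change at the digits printed from compound 1 to compound 4 (within the scatter) and so leaves the number where it stood. Among these four compounds, the two phenoxy compounds stand together above the isobutyl and phenethyl compounds, and none goes against that split.

As far as these compounds go, whether a phenoxy ring carrying an amine or a carboxylic acid, or a phenyl ring joined directly to this carbon, would stay at that level remains open. No supporting measurement is available to explain the split.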